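Lengthening the Sulfonamide Chain in a Weakly Cytotoxic Series

The source may hold more compounds than are shown below. What is called first, only, known or untested is meant among the compounds shown, and "the series" means these compounds.

Of the compounds shown here, two sharing one core have been tested in an ADME assay on RAW264.7 cells (Mus musculus) for cytotoxicity, read by MTT assay, with a stated time of 48 h; on this read-out lower numbers stand for stronger inhibition and higher numbers for weaker inhibition. Compound 1 `CCS(=O)(=O)Nc1ccc(NC(=O)c2ccc(C#N)cc2)cc1C` gives 109000 nM in this assay, a number inside the range the assay can report. Compound 2 `CS(=O)(=O)Nc1ccc(NC(=O)c2ccc(C#N)cc2)cc1Cl` differs from compound 1 in more than one place, so the two values are only set side by side here. In this assay compound 2 gives > 250000 nM, which is a limit of the assay rather than a measured number. Compound 2 stands at the limit of > 250000 nM in this assay, at which 1 of the 2 values shown sits, the point where the read-out ends and only a bound on its half-maximal inhibitory concentration is known.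

Compound 3 `CCS(=O)(=O)Nc1ccc(NC(=O)c2ccc(C#N)cc2)cc1Cl` has not yet been measured. It differs from compound 2 by one change: methyl in place of hydrogen on a saturated chain carbon bound to a sulfonyl sulfur, which turns a methanesulfonamido group into an (ethylsulfonyl)amino group. Among the compounds with values here, no measured pair in this set isolates that change, so no step can be read off directly. The one carbon that enters is a small alteration, and no shift beyond the scatter of this assay is expected from it. Compound 3 is expected to give 200000 nM in this assay, within 80000 nM to 500000 nM. The step from compound 2 to compound 3 is estimated at an at least 1.2-fold lower number from compound 2 to compound 3 (0.09 log units; that floor lies within the scatter). Since compound 2 sits at a limit, a fair chance remains that compound 3 is also reported only as a limit.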

Compound 3, half-maximal inhibitory concentration: 226000 nM
Beside the measured number, compound 3's estimate is 1.1-fold (0.05 log units) below it; measured number inside the range.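

In this assay, going by these compounds, the change from methanesulfonamido to (ethylsulfonyl)amino can now be read with the chloro group held fixed, and it comes out as an at least 1.1-fold lower number from compound 2 to compound 3 (0.04 log units; that floor lies within the scatter) and so gives no sign that this one added carbon matters, although that figure is only a floor and the true size of the step stays unknown. The floor is all that can be read here, as compound 2 gives a limit and not a number: the limit of > 250000 nM in this assay, at which 1 of the 3 values shown sits. Compound 1 and compound 3 form the first pair with two real numbers, and chloro in place of methyl on an aromatic carbon gives a 2.1-fold higher number from compound 1 to compound 3 (0.32 log units; beyond the scatter) with the (ethylsulfonyl)amino group unchanged, which makes this the only change shown so far that clearly moves the read-out, if only modestly.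

On these data alone, whether a longer chain such as propyl or butyl on the sulfonyl sulfur would leave the number just as flat remains open. As far as these compounds go, it is also open whether a fluoro or methoxy group in place of the chloro would carry the read-out further in either direction.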